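One Side-Arm Change, One Measurement Still to Come

A few compounds are considered here, and "the series" means these few. Any claim that something is new, unique, unknown or untested is made for them only; others in the source may bear on it.

Compound 1 `c1ccc(CC2CCN(CCCc3c[nH]c4ccc(-n5cnnc5)cc34)CC2)cc1`, 0.3 nM
Compound 2 `FC1(Cc2ccccc2C(F)(F)F)CCN(CCCc2c[nH]c3ccc(-n4cnnc4)cc23)CC1`, 0.3 nM

In an assay on CHO cells for displacement of a labelled ligand from 5-hydroxytryptamine receptor 1D (Homo sapiens) (on this read-out higher numbers stand for weaker inhibition and lower numbers for stronger inhibition), compound 1 gives 0.3 nM. Compound 2 in this assay gives 0.3 nM, level with compound 1 at the digits shown, so the two stand within the usual scatter of each other. Among the compounds with values here, no step between measured compounds is available that differs in a single place, so nothing on record tells how much room this assay leaves for change around the shared core.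

Compound 3 `Fc1ccc(CCC2(F)CCN(CCCc3c[nH]c4ccc(-n5cnnc5)cc34)CC2)cc1` is the next compound to be measured. It differs from compound 2 in one place: 4-fluorobenzyl in place of 2-(trifluoromethyl)phenyl on a saturated chain carbon bound to a saturated ring carbon. Compound 3 is expected to stay close to compound 2, with the step of a 1.7-fold higher number from compound 2 to compound 3 (0.22 log units; within the scatter) of small size and at most a slight weakening, hardly beyond the scatter. The estimate for compound 3 in this assay is 0.5 nM, with a range from 0.15 nM to 2 nM.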

Compound 3, half-maximal inhibitory concentration: 1 nM
Compound 3: middle estimate off by 2.0-fold (0.30 log units), on the low side; measured number inside the range.
By their numbers in this assay, from the lowest: compounds 1 and 2 (each within the scatter of the next); then compound 3.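

In this assay, the change from 2-(trifluoromethyl)phenyl to 4-fluorobenzyl on a saturated chain carbon bound to a saturated ring carbon gives a 3.3-fold higher number from compound 2 to compound 3 (0.52 log units; beyond the scatter) and this modest step lies beyond the scatter. Within the data shown here, it is the first sign on record that the assay responds to a change around the shared core, and that this side arm can move the number, though only modestly. No supporting measurement bears on the reason for the shift.

Read one bond further out, the same step is 2-(trifluoromethyl)benzyl to 2-(4-fluorophenyl)ethyl, so the ring substituent and the chain change together, and the compounds shown do not separate the two. Also open, from the compounds shown here alone, is how the number would respond to an amine or a carboxylic acid on this side arm.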